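The source may hold more compounds than are shown below. What is called first, only, known or untested is meant among the compounds shown, and "the series" means these compounds.

In a functional assay on Maver1 cells (Homo sapiens) for inhibition, read by luminescence and CellTiter-Glo, with a stated time of 72 h (on this read-out lower numbers stand for stronger inhibition and higher numbers for weaker inhibition), compound 3 `C=CC(=O)N1CCCC(n2nc(-c3ccc(Oc4ccccc4)cc3)cc2C(=O)OCC)C1` gives only a limit, > 60000 nM, which places it at the limit of > 60000 nM in this assay, at which 1 of the 3 values shown sits. Compound 4 `CCOC(=O)c1cc(-c2ccc(Oc3ccccc3)cc2)nn1C1CCCN(C(=O)CCl)C1` carries one change, chloromethyl in place of vinyl on a carbonyl carbon. Within the data shown here, compound 2 `C/C=C/C(=O)N1CCCC(n2nc(-c3ccc(Oc4ccccc4)cc3)cc2C(=O)OCC)C1`, at 19600 nM, supplies the only measured step at this place, an at least 3.0-fold higher number from compound 2 to compound 3 (0.48 log units; beyond the scatter), which lies beyond the scatter. The chloromethyl on a carbonyl carbon also occurs in compound 1 `O=C(CCl)N1CCCC(n2nc(-c3ccc(Oc4ccccc4)cc3)cc2CO)C1`, which gives 1100 nM, but that compound differs elsewhere. A lower number is therefore expected in this assay, though the limit leaves the size open. The expected change is an at least 7.5-fold lower number from compound 3 to compound 4 (0.87 log units; beyond the scatter). For compound 4 the estimate is 8000 nM, with an expected range of 1500 nM to 40000 nM.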

Compound 4, half-maximal inhibitory concentration: 1200 nM
Estimate against measurement, compound 4: 6.7-fold (0.82 log units) above; the measured number lies below the stated range.
By their numbers in this assay, from the lowest: compounds 1 and 4 (each within the scatter of the next); then compound 2. At a limit, above all of these: compound 3.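

Compound 3 gives only a limit in this assay: the limit of > 60000 nM in this assay, at which 1 of the 4 values shown sits.
On the carbonyl carbon, chloromethyl gives the lower number against both other groups, with an at least 50-fold lower number from compound 3 to compound 4 (1.69 log units; beyond the scatter) and a 16-fold lower number from compound 2 to compound 4 (1.21 log units; beyond the scatter). With chloromethyl on that carbon, the group on the aromatic carbon makes no difference beyond the scatter, with a 1.1-fold higher number from compound 1 to compound 4 (0.04 log units; within the scatter), so ethoxycarbonyl and hydroxymethyl read alike.

Still open, going by these compounds, is whether bromomethyl or a longer chain on the carbonyl carbon, or a carboxylic acid or an amine on the aromatic carbon, would hold this level.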